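Imidazole carboxamide in place of bromobenzamide in the series

The compounds below may be only part of what the source reports. "The series", "measured", "known", "first", "only" and "open" are said of these compounds alone.

Compound 2 `Cn1c(-c2ccccc2)cnc1NC(=O)c1ccc(Br)cc1` is the reference point for this step. In a toxicity assay on THP-1 cells (Homo sapiens) for inhibition (on this read-out higher numbers stand for lower toxicity in this test and lower numbers for higher toxicity in this test), compound 2 gives > 100000 nM, which is a limit of the assay and not a measured number. Compound 1 `COc1ccc(-c2cnc(NC(=O)c3ccc(Br)cc3)n2C)cc1` carries a methoxy on an aromatic carbon where compound 2 has hydrogen. In this assay compound 1 gives > 100000 nM, likewise a limit. Compound 3 `COc1ccc(-c2cnc(NC(=O)c3ccccc3Br)n2C)cc1` has 2-bromophenyl in place of 4-bromophenyl on the carbonyl carbon. In this assay compound 3 gives > 100000 nM, again a limit. The two measured steps are a step that the two limits leave unreadable from compound 1 to compound 2 and a step that the two limits leave unreadable from compound 1 to compound 3; their size cannot be read because every value sits at the limit of > 100000 nM in this assay, at which 3 of the 3 values shown sit. Compound 2 therefore stands at the ceiling of what the assay reports, together with every other measured compound.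

Compound 4 `Cn1c(-c2ccccc2)cnc1NC(=O)c1ncc[nH]1` differs from compound 2 by 1H-imidazol-2-yl in place of 4-bromophenyl on a carbonyl carbon. Neither measured step touches the group on the carbonyl carbon in this way, and neither gives a readable size, so no change beyond the scatter can be predicted; the working expectation is that the limit is reached again. Compound 4 is expected to give 120000 nM in this assay, within a range from 50000 nM to 300000 nM. This estimate implies a step that the limit leaves unreadable from compound 2 to compound 4, expected to lie within the scatter.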

Compound 4, half-maximal cytotoxic concentration: > 100000 nM
Compound 4: a limit, no number; the forecaster's own chance of this, stated with the estimate: 85%; the middle value lies beyond the limit too.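

In this assay compound 4 gives > 100000 nM, a limit and not a number. No step can be read from compound 2 to compound 4 because both values sit at the same limit: the limit of > 100000 nM in this assay, at which 4 of the 4 values shown sit.

The compounds shown leave open whether 1H-imidazol-2-yl and 4-bromophenyl on the carbonyl carbon differ at all in this test.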